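The source may report more compounds than this note shows. Statements on the series, on what has been measured and on what is new or still open speak of the compounds shown alone.

Measured to date in an assay on isolated protein for inhibition of protein tyrosine phosphatase type IVA 3 (Homo sapiens), tested at 5 ug/mL; a higher number here means more inhibition at the concentration tested (going by the name of the read-out), a lower number less inhibition:

- compound 1 `O=C1NC(=S)S/C1=C\C=C\c1ccccc1OCc1ccccc1C(F)(F)F`: 40.8%
- compound 2 `O=C1NC(=S)S/C1=C\C=C\c1ccccc1OS(=O)(=O)c1ccccc1`: 64.2%
- compound 3 `O=C1NC(=O)/C(=C/C=C/c2ccccc2OCc2ccccc2Br)S1`: 22.5%

Three compounds measured, none differing from another in only one place, so no single-change step can be read from them. Compound 1 stands second highest of the three numbers. Its nearest neighbour in this assay is compound 3, a number lower by a margin beyond the scatter; the furthest is compound 2, higher by a margin also beyond the scatter. Compound 3 also carries a different ring in the shared core from the other two, so its lower number cannot be assigned to any one part of the structure.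

Next up is compound 4 `O=C1NC(=S)S/C1=C\C=C\c1ccccc1OCc1ccccc1`, still to be measured in this assay. Against compound 1 the change is hydrogen in place of trifluoromethyl on an aromatic carbon. Going by the values given here, no measured pair shows the effect of this change, so the expectation rests on compound 1 alone. The step from compound 1 to compound 4 is expected to be small, most likely a modest drop, though a step within the scatter or none at all would not surprise. Compound 4 is expected to give about 35% in this assay, with a range from 15% to 55%, which is an expected step of a number 5.8 percentage points lower from compound 1 to compound 4 (within the scatter).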

Compound 4, a percentage reported as inhibition, at one concentration (the size of the read-out at that concentration, not a potency): 49.5%
Estimate against measurement, compound 4: 14.5 percentage points below, within the range that was stated.
By their numbers in this assay, from the lowest: compound 3; then compounds 1 and 4 (each within the scatter of the next); then compound 2.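

In this assay, going by these compounds alone, compounds 1 and 4 form the first pair that differs in one place, and hydrogen in place of trifluoromethyl on an aromatic carbon, ortho to a large group, gives a number 8.7 percentage points higher from compound 1 to compound 4 (within the scatter). At this place, then, the read-out does not separate the trifluoromethyl compound from the unsubstituted one, so the group with its 4 heavy atoms makes no difference here that stands clear of the scatter. Nothing available bears on the reason for this result.

This single pair does not show how other groups on the same aromatic carbon would read, such as an amine, a carboxylic acid or a methoxy group, nor whether the same change would read alike on the core of compound 3. Steps linking compound 2 or compound 3 to the others cannot be read, since neither differs from compound 1 or compound 4 in one place only, so the contributions of their linking group, bromine and core remain unresolved.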